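Vinylsulfonyl replaces vinylcarbonyl on a well-tolerated compound

The source may hold more compounds than are shown below. What is called first, only, known or untested is meant among the compounds shown, and "the series" means these compounds.

In an ADME assay on MT4 cells (Homo sapiens) for cytotoxicity, read by MTT assay, with a stated time of 5 days (a lower number here means that less compound is tolerated, a higher number that more compound is tolerated), compound 3 (`C=CC(=O)NC1CCN(S(=O)(=O)c2c(C(N)=O)[nH]c3ccc(Br)cc23)CC1`) reads > 274000 nM, which is a limit of the assay and not a number. Compound 4 (`C=CS(=O)(=O)NC1CCN(S(=O)(=O)c2c(C(N)=O)[nH]c3ccc(Br)cc23)CC1`) carries vinylsulfonyl in place of vinylcarbonyl on an amine nitrogen. The nearest guide is a different pair, which also differs elsewhere in structure. Compound 1 (`C=CC(=O)N1CC[C@@H](NS(=O)(=O)c2c(C(N)=O)[nH]c3ccc(Br)cc23)C1`), with vinylcarbonyl, reads 51800 nM, while compound 2 (`C=CS(=O)(=O)N1CC[C@H](NS(=O)(=O)c2c(C(N)=O)[nH]c3ccc(Br)cc23)C1`), with vinylsulfonyl, reads 16000 nM. A moderate change toward a lower number in this assay, meaning less compound tolerated, is therefore expected, although the limit leaves the starting point open. The expected size is an at least 3.4-fold lower number from compound 3 to compound 4 (0.53 log units; beyond the scatter). Compound 4 is estimated at 80000 nM, with an expected range from 25000 nM to 250000 nM.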

Compound 4, half-maximal cytotoxic concentration: 6500 nM
The estimate for compound 4 lay 12-fold (1.09 log units) above the measured number, and the stated range ends above it.
By their numbers in this assay, from the lowest: compound 4; then compound 2; then compound 1. At a limit, above all of these: compound 3.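

Here the change from vinylcarbonyl to vinylsulfonyl can be read on its own for the first time, on an amine nitrogen attached to a saturated ring carbon: in this assay it gives an at least 42-fold lower number from compound 3 to compound 4 (1.62 log units; beyond the scatter), a large step. For compound 3, > 274000 nM is a limit of the assay and not a number. The true size of the step therefore stays unknown because of this limit: the limit of > 274000 nM in this assay, at which 1 of the 4 values shown sits.

On these data alone, it remains open how a saturated propanoyl group or a methylsulfonyl group on the same nitrogen would read. Whether the vinyl part or the sulfonyl part drives the step is also unresolved.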